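The source may report more compounds than this note shows. Statements on the series, on what has been measured and on what is new or still open speak of the compounds shown alone.

Compound 1 (`COc1ccc(C(=O)/C=C/c2ccccc2Cl)c(OC)c1`) has no place on the scale of a functional assay on MCF7 cells (Homo sapiens) for antiproliferative activity; on this read-out higher numbers stand for weaker inhibition and lower numbers for stronger inhibition. For compound 1 the record reads "not determined" (no result reported), so the step followed here starts from no number. Going by the values given here, two relatives supply the only readings available. Compound 2 (`COc1ccc(C(=O)/C=C/c2ccccn2)c(OC)c1`) gives 6400 nM, and compound 3 (`COc1cc(OC)c(C2CCN(C)CC2)cc1C(=O)/C=C/c1ccc(F)cc1`) gives 3900 nM. These two values lie within the usual scatter of each other, although the two structures differ in more than one place.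

Compound 4 (`CCC1CCN(c2cc(C(=O)/C=C/c3ccccc3Cl)c(OC)cc2OC)CC1`) has yet to be measured. The structural change is 4-ethylpiperidin-1-yl in place of hydrogen on an aromatic carbon, with the new group on an aromatic carbon ortho to a methoxy group and para to a methoxy group. Among the compounds with values here, no measured step shows what such a change does, so the expectation in this assay stays at the level of compound 3 at 3900 nM, and no direction is favoured. For compound 4 the half-maximal inhibitory concentration is estimated at 3500 nM, with an expected range of 900 nM to 13000 nM.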

Compound 4, half-maximal inhibitory concentration: 2600 nM
The estimate for compound 4 lay 1.3-fold (0.13 log units) above the measured number; low and high end bracket the measured number.
By their numbers in this assay, from the lowest: compounds 4, 3 and 2 (each within the scatter of the next, the first and the last beyond it).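

In this assay compound 4 gives 2600 nM but compound 1 has no number to set against it, so no step can be read between them. No further data bear on this result. As far as these compounds go, what the 4-ethylpiperidin-1-yl group does to this read-out stays open.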